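A few compounds are considered here, and "the series" means these few. Any claim that something is new, unique, unknown or untested is made for them only; others in the source may bear on it.

The study concerns a small set of compounds that share a core and are tested in a functional assay on IGROV-1 cells (Homo sapiens) for inhibition, read by sulforhodamine B assay, with a stated time of 48 h, tested at 10 uM; a lower number here means a stronger effect, a higher number a weaker effect of the compound at the concentration tested. Compound 1, `O=C(Nc1cccc(-n2cc(-c3ccncc3)c(-c3cc(O)cc(Cl)c3)n2)c1)Nc1ccc(Cl)c(Cl)c1`, gives 26% in this assay. Compound 2, `COc1cc(Cl)cc(-c2nn(-c3cccc(NC(=O)Nc4ccc(Cl)c(Cl)c4)c3)cc2-c2ccncc2)c1`, differs from compound 1 only by one change, (methyl in place of hydrogen on an oxygen on an aromatic ring), and in this assay compound 2 gives 36.7%. The step of a number 10.7 percentage points higher from compound 1 to compound 2 (beyond the scatter) is therefore a modest weakening of the effect at the concentration tested.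

Compound 3, `O=C(Nc1cccc(-n2cc(-c3ccncc3)c(-c3cc(O)cc(Cl)c3)n2)c1)c1cc(C(F)(F)F)cc(C(F)(F)F)c1`, carries a different core from compound 1; the difference between the two cores is not broken down here. In this assay compound 3 gives 73%, the highest of the three numbers and beyond the scatter from both compound 1 and compound 2.

Compound 4, `COc1cc(Cl)cc(-c2nn(-c3cccc(NC(=O)c4cc(C(F)(F)F)cc(C(F)(F)F)c4)c3)cc2-c2ccncc2)c1`, has not yet been measured. It stands to compound 3 as compound 2 stands to compound 1, by the same change, (methyl in place of hydrogen on an oxygen on an aromatic ring), at the same place. If the step seen from compound 1 to compound 2 carries over to the second core, compound 4 is expected to show a step of a number 7 percentage points higher from compound 3 to compound 4 (within the scatter) in this assay, resting on the single earlier pair and on the already high value of compound 3. Compound 4 is therefore estimated at 80% in this assay, with a likely range from 62% to 98%.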

Compound 4, a percentage reported as activity, at one concentration (the size of the read-out at that concentration, not a potency): 100%
For compound 4 the middle estimate is 20 percentage points below the measured one, outside the stated range (above it).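

In this assay the change from hydroxy to methoxy gives a number 27 percentage points higher from compound 3 to compound 4 (beyond the scatter) and so moves the number in the same direction on both cores shown, towards a weaker effect at the concentration tested. The direction of the change carries from the core of compound 1 to the core of compound 3, but its size does not: the same change on two cores in this assay, a number 10.7 percentage points higher (beyond the scatter) from compound 1 to compound 2 and a number 27 percentage points higher (beyond the scatter) from compound 3 to compound 4, 16.3 percentage points apart, beyond the scatter of two such steps. Among the compounds shown here, this rests on only two pairs, each read at a single concentration, so it does not show why the two steps differ in size, how the change would behave on any further core, or how the effect would shift at any other concentration.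

The compounds shown carry only hydroxy or methoxy at this place, which leaves open what an ethoxy group, a longer chain or an amine on the same aromatic ring would do on either core. Also open, as far as these compounds go, is which part of the difference between the two cores goes with the gap between the steps, since the cores are compared here only as wholes.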